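From fluoro to trifluoromethyl on an aromatic carbon

The source may hold more compounds than are shown below. What is called first, only, known or untested is meant among the compounds shown, and "the series" means these compounds.

In a functional assay on K562 cells (Homo sapiens) for cytotoxicity, read by MTT assay, with a stated time of 24 h (a higher number here means a weaker inhibitor, a lower number a stronger inhibitor), compound 1 `CN1C/C(=C\c2ccc(F)cc2)C(=O)/C(=C/c2cccc([N+](=O)[O-])c2)C1` gives 11300 nM and compound 2 `CN1C/C(=C\c2cccc([N+](=O)[O-])c2)C(=O)/C(=C/c2ccc(Cl)cc2Cl)C1` gives 12400 nM while compound 3 `CN1C/C(=C\c2cccc(Br)c2)C(=O)/C(=C/c2cccc([N+](=O)[O-])c2)C1` gives 12200 nM with all three within the scatter of one another, so compound 1 stands level with the other two. Compound 4 `CN1C/C(=C\c2ccc(C(F)(F)F)cc2)C(=O)/C(=C/c2cccc([N+](=O)[O-])c2)C1` carries trifluoromethyl in place of fluoro on an aromatic carbon, para to a large group (trifluoromethyl in place of fluoro on an aromatic carbon). Both measured replacements of the 4-fluorophenyl group gave small steps (a 1.1-fold higher number from compound 1 to compound 2 (0.04 log units; within the scatter)) and (a 1.1-fold higher number from compound 1 to compound 3 (0.03 log units; within the scatter)) that stay within the scatter. The step expected in this assay is therefore none beyond the scatter, estimated as a 1.0-fold higher number from compound 1 to compound 4 (0.01 log units; within the scatter) in size. Compound 4 is expected at 11500 nM with an estimated range of 6500 nM to 19000 nM in this read-out.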

Compound 4, half-maximal inhibitory concentration: 4780 nM
Compound 4: the middle estimate sits 2.4-fold (0.38 log units) above what was measured; measured number outside the range, below it.
By their numbers in this assay, from the lowest: compound 4; then compounds 1, 3 and 2 (each within the scatter of the next).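

In this assay, trifluoromethyl in place of fluoro gives a 2.4-fold lower number from compound 1 to compound 4 (0.37 log units; beyond the scatter), the only step shown here that lies beyond the scatter. The 2,4-dichlorophenyl and 3-bromophenyl replacements of the 4-fluorophenyl group left the number within the scatter, so this aryl group does respond to at least one change on an aromatic carbon, para to a large group. Nothing measured on these compounds bears on why the step arises. Still open, from the compounds shown here alone, is whether a nitrile, a methoxy group or an amine on that carbon would move the number the same way as trifluoromethyl.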